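This account rests on a few compounds, and the source may have more. Where it says the series, first, only, none or still open, it means among the compounds named here.

Of the compounds shown here, three with a shared core have been measured in an ADME assay on HaCaT cells (Homo sapiens) for antiproliferative activity, read by MTT assay, with a stated time of 48 h; a higher number here means a weaker inhibitor, a lower number a stronger inhibitor. Compound 1 (`COc1ccc(N/C=C\C(=O)c2cn(-c3ccccc3)nc2-c2ccc(OC)cc2)cc1`) returns only a limit of the assay, > 50000 nM. This is the limit of > 50000 nM in this assay, at which 1 of the 3 values shown sits. Compound 2 (`COc1cc(-c2nn(-c3ccccc3)cc2C(=O)/C=C\Nc2ccc(F)cc2)cc(OC)c1OC`) gives 25700 nM, and compound 3 (`COc1cc(-c2nn(-c3ccccc3)cc2C(=O)/C=C\Nc2ccc(O)cc2)cc(OC)c1OC`) gives 17600 nM. Within the data shown here, the single one-place step measured so far is a 1.5-fold lower number from compound 2 to compound 3 (0.16 log units; within the scatter). Among the two numbers compound 3 stands at the lower one, though its gap to compound 2 is within the scatter, and compound 1 sits at a limit.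

Compound 4 (`COc1ccc(N/C=C\C(=O)c2cn(-c3ccccc3)nc2-c2cc(OC)c(OC)c(OC)c2)cc1`) is not yet measured. It differs from compound 3 by methyl in place of hydrogen on an oxygen on an aromatic ring. The step from compound 2 to compound 3 also exchanged the substituent of the (4-hydroxyphenyl)amino group and stayed within the scatter, so another exchange there is expected to move this assay little; the expected step is a 1.4-fold higher number from compound 3 to compound 4 (0.13 log units; within the scatter). Compound 4 is accordingly estimated at 24000 nM, with a range from 10000 nM to 55000 nM.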

Compound 4, half-maximal inhibitory concentration: > 50000 nM
Compound 4 ended at the assay's limit (the forecaster's own chance of this, stated with the estimate: 20%); middle value at least 2.0-fold (0.31 log units) away from the limit.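

Methyl in place of hydrogen on the oxygen of the 4-hydroxyphenyl group gives an at least 2.8-fold higher number from compound 3 to compound 4 (0.45 log units; beyond the scatter). Among these compounds, this is the first step at this position to lie beyond the scatter, whereas the earlier exchange there gave only a 1.5-fold lower number from compound 2 to compound 3 (0.16 log units; within the scatter). Measured against fluoro, methoxy gives an at least 1.9-fold higher number from compound 2 to compound 4 (0.28 log units; that floor lies within the scatter), so only the hydroxy-to-methoxy change separates clearly, and compound 4 ends at a limit, as compound 1 does: the limit of > 50000 nM in this assay, at which 2 of the 4 values shown sit.

As far as these compounds go, the step between compound 1 and compound 4 cannot be read, with both at limits, so the effect of 3,4,5-trimethoxyphenyl in place of 4-methoxyphenyl stays open. Also open, from the compounds shown here alone, are the true value of compound 4 and how an amine, a carboxylic acid or a longer ethoxy chain on this aromatic carbon would read.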